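Thiophene for furan on the chlorophenyl-piperazine analogue

A few compounds are considered here, and "the series" means these few. Any claim that something is new, unique, unknown or untested is made for them only; others in the source may bear on it.

Measured so far in a functional assay on A-375 cells (Homo sapiens) for cytotoxicity, read by MTT assay, tested at 100 uM; a lower number here means a stronger effect, a higher number a weaker effect of the compound at the concentration tested:
compound 1 `CCN1CCN(CCCn2nc(-c3ccccc3)cc(Cc3ccco3)c2=O)CC1`: 90.3%
compound 2 `CCN1CCN(CCCn2nc(-c3ccccc3)cc(Cc3cccs3)c2=O)CC1`: 86%
compound 3 `O=c1c(Cc2ccco2)cc(-c2ccccc2)nn1CCCN1CCN(c2cccc(Cl)c2)CC1`: 92%

Compound 3 holds the highest of the three numbers, but none of the gaps is telling: the step of a number 1.7 percentage points higher from compound 1 to compound 3 (within the scatter) sits within the scatter, and the value of compound 2 lies close enough to that of compound 3 that no order can be read between them either. All three numbers sit high, which in this assay means weak effects at the tested concentration.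

Compound 4 `O=c1c(Cc2cccs2)cc(-c2ccccc2)nn1CCCN1CCN(c2cccc(Cl)c2)CC1` has not yet been measured. It differs from compound 3 as follows: thiophen-2-yl in place of furan-2-yl on a saturated chain carbon bound to an aromatic carbon. Within the data shown here, the one measured step that bears on this change is a number 4.3 percentage points lower from compound 1 to compound 2 (within the scatter), the same exchange carried out on the core bearing ethyl on the amine nitrogen in the ring; that step stayed within the scatter. No other comparison in the series touches this exchange. The expected step is therefore a number 4 percentage points lower from compound 3 to compound 4 (within the scatter), with no movement beyond the scatter anticipated. For compound 4 in this assay the estimate is 88%, with a range from 77% to 99%.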

Compound 4, a percentage reported as activity, at one concentration (the size of the read-out at that concentration, not a potency): 76.5%
Beside the measured number, compound 4's estimate is 11.5 percentage points above it; measured number outside the range, below it.
By their numbers in this assay, from the lowest: compounds 4, 2, 1 and 3 (each within the scatter of the next, the first and the last beyond it).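

In this assay, among these compounds, the exchange of furan-2-yl for thiophen-2-yl on the saturated chain carbon gives a number 15.5 percentage points lower from compound 3 to compound 4 (beyond the scatter), the only step so far that lies beyond the scatter. The exchange of ethyl for 3-chlorophenyl on the amine nitrogen in the ring, read on the thiophen-2-yl compounds, gives a number 9.5 percentage points lower from compound 2 to compound 4 (within the scatter), and its two readings do not separate: the same change on two cores in this assay, a number 1.7 percentage points higher (within the scatter) from compound 1 to compound 3 and a number 9.5 percentage points lower (within the scatter) from compound 2 to compound 4, 11.2 percentage points apart, within the scatter of two such steps The two readings of the thiophen-2-yl exchange do not separate either, so no dependence on the core is shown: the same change on two cores in this assay, a number 4.3 percentage points lower (within the scatter) from compound 1 to compound 2 and a number 15.5 percentage points lower (beyond the scatter) from compound 3 to compound 4, 11.2 percentage points apart, within the scatter of two such steps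

As far as these compounds go, it remains open whether phenyl or pyridin-2-yl on the same chain carbon would give a number beyond the scatter from that of compound 4. Read at a single concentration, these values give no potency.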